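A Fluorinated Chain Replaces the Sulfonamide on the Shared Core

This account rests on a few compounds, and the source may have more. Where it says the series, first, only, none or still open, it means among the compounds named here.

compound 1, `Cn1c(-c2ccccc2C(F)(F)F)nnc1C12CCC(CNS(C)(=O)=O)(CC1)CC2`: > 4000 nM (a limit of the assay)
compound 2, `Cn1c(-c2ccccc2C(F)(F)F)nnc1C12CCC(CCCC(C)(F)F)(CC1)CC2`: > 4000 nM (a limit of the assay)
compound 3, `Cn1c(-c2ccccc2C(F)(F)F)nnc1C12CCC(COc3ccc(S(C)(=O)=O)cc3)(CC1)CC2`: > 4000 nM (a limit of the assay)

All three compounds share one core and differ only in the group on a saturated chain carbon bound to a saturated ring carbon. In an assay on CHO-K1 cells for inhibition of 11-beta-hydroxysteroid dehydrogenase type 2 (Mus musculus), read by scintillation proximity assay (a higher number here means a weaker inhibitor, a lower number a stronger inhibitor), compound 1 stands only at a limit of the assay, so its position cannot be placed more finely. Compound 4, `CC(F)CCCC12CCC(c3nnc(-c4ccccc4C(F)(F)F)n3C)(CC1)CC2`, carries 3-fluorobutyl in place of methanesulfonamido on a saturated chain carbon bound to a saturated ring carbon. The measured changes that bear on this are a step that the two limits leave unreadable from compound 1 to compound 2, a step that the two limits leave unreadable from compound 1 to compound 3 and a step that the two limits leave unreadable from compound 2 to compound 3. Because every value sits at the limit of > 4000 nM in this assay, at which 3 of the 3 values shown sit, none of these steps can be sized. The new chain most resembles that of compound 2, which also gives only a limit in this assay. No movement beyond the scatter can be read, and the expected step is a step that the limit leaves unreadable from compound 1 to compound 4. Compound 4 is therefore estimated at 8000 nM, ranging from 3000 nM to 30000 nM.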

Compound 4, half-maximal inhibitory concentration: > 4000 nM
Compound 4 was reported as a limit (the forecaster's own chance of this, stated with the estimate: 85%); the middle value lies beyond the limit too.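

For the compounds shown here, no step from compound 1, compound 2 or compound 3 to compound 4 can be read in this assay, because all four compounds stand at a limit: the limit of > 4000 nM in this assay, at which 4 of the 4 values shown sit. Which group on the shared core would give an actual number in this assay stays open.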